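The source may hold more compounds than are shown below. What is called first, only, known or untested is meant among the compounds shown, and "the series" means these compounds.

Compound 3 `COc1cc2nnc(C(N)=O)c(Nc3ccc(C)cc3F)c2cc1N1CCC(OC)CC1` gives 0.012 in an ADME assay on a cell-free system (plasma, Rattus norvegicus) for protein binding (on this read-out lower numbers stand for a smaller free fraction and higher numbers for a larger free fraction), the lowest of the three numbers measured. Compound 1 `COc1cc2nnc(C(N)=O)c(Nc3ccc(C)cc3F)c2cc1N1CCCN(C)CC1` gives 0.103 and compound 2 `COc1cc2nnc(C(N)=O)c(Nc3ccc(C)cc3F)c2cc1N1CCC(N(C)C)CC1` gives 0.15 in this assay; the step of a 1.5-fold higher number from compound 1 to compound 2 (0.16 log units; within the scatter) separates them. The group changed in compound 3 was reached by an 8.6-fold lower number from compound 1 to compound 3 (0.93 log units; beyond the scatter) and a 13-fold lower number from compound 2 to compound 3 (1.10 log units; beyond the scatter), both moving toward a smaller free fraction. Compound 4 `COc1cc2nnc(C(N)=O)c(Nc3ccc(C)cc3F)c2cc1N1CCN(S(C)(=O)=O)CC1` carries 4-(methylsulfonyl)piperazin-1-yl in place of 4-methoxypiperidin-1-yl on an aromatic carbon. Among the measured compounds shown here, no measured step covers this entering group, so its effect cannot be read from the data; the two steps that bear on the leaving group suggest only that a change here can move the number substantially. A moderate step upward is expected, a 2.1-fold higher number from compound 3 to compound 4 (0.32 log units; beyond the scatter), with compound 4 estimated at 0.025, between 0.008 and 0.07.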

Compound 4, unbound fraction: 0.091
For compound 4 the middle estimate is 3.6-fold (0.56 log units) below the measured one; the measured number lies above the stated range.
By their numbers in this assay, from the lowest: compound 3; then compounds 4, 1 and 2 (each within the scatter of the next).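

In this assay, 4-(methylsulfonyl)piperazin-1-yl gives a 7.6-fold higher number from compound 3 to compound 4 (0.88 log units; beyond the scatter), while a 1.6-fold lower number from compound 2 to compound 4 (0.22 log units; within the scatter) and a 1.1-fold lower number from compound 1 to compound 4 (0.05 log units; within the scatter) remain within the scatter. Among the four groups shown on this aromatic carbon, the small free fraction thus stands with 4-methoxypiperidin-1-yl alone, and a number in the range of the other two groups does not require dimethylamino or the 4-methyl-1,4-diazepan-1-yl ring. Nothing available explains this difference. On these data alone, it remains open which part of 4-methoxypiperidin-1-yl goes with the low number, and whether a 4-hydroxypiperidin-1-yl or morpholin-4-yl group would stay near compound 3 or near the other three.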